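The source may report more compounds than this note shows. Statements on the series, on what has been measured and on what is new or still open speak of the compounds shown alone.

In an ADME assay on L02 cells (Homo sapiens) for cytotoxicity, read by MTT assay, with a stated time of 24 h (a lower number here means a stronger inhibitor, a higher number a weaker inhibitor), compound 1 (`COc1cc(/C=C2\CN(C)C/C(=C\c3ccc(F)cc3)C2=O)cc(OC)c1OC`) gives 10700 nM and compound 2 (`COc1cc(/C=C2\CN(C)C/C(=C\c3ccc(Cl)c(Cl)c3)C2=O)cc(OC)c1OC`) gives 18400 nM, so compound 2 stands level with compound 1 within the scatter. Compound 3 (`COc1cc(/C=C2\CN(C)C/C(=C\c3ccc(C#N)cc3)C2=O)cc(OC)c1OC`) is next, with 4-cyanophenyl in place of 3,4-dichlorophenyl on a double-bonded chain carbon bound to a double-bonded ring carbon. Going by the values given here, the one measured step at this place, a 1.7-fold higher number from compound 1 to compound 2 (0.24 log units; within the scatter), stays within the scatter, so no step beyond the scatter is expected in this assay. The expected change is a 1.4-fold lower number from compound 2 to compound 3 (0.15 log units; within the scatter). Compound 3 is estimated at 13000 nM, with an expected range of 5500 nM to 30000 nM.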

Compound 3, half-maximal inhibitory concentration: 18600 nM
Estimate against measurement, compound 3: 1.4-fold (0.16 log units) below; measured number inside the range.
By their numbers in this assay, from the lowest: compounds 1, 2 and 3 (each within the scatter of the next).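

In this assay a 4-cyanophenyl group, which brings a triple bond and a hydrogen-bond acceptor, gives a 1.0-fold higher number from compound 2 to compound 3 (0.00 log units; within the scatter) against 3,4-dichlorophenyl. The comparison with the 4-fluorophenyl compound gives a 1.7-fold higher number from compound 1 to compound 3 (0.24 log units; within the scatter) for cyano in place of fluoro on an aromatic carbon, so all three aryl groups at this place now sit within the scatter. Nothing on hand accounts for this result. From the compounds shown here alone, whether an amine, a carboxylic acid or a longer chain on this carbon would stay within the scatter remains open.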